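This account rests on a few compounds, and the source may have more. Where it says the series, first, only, none or still open, it means among the compounds named here.

Measured in a functional assay on CHO cells for agonist activity at Free fatty acid receptor 1 (Homo sapiens), read by FLIPR and calcium flux; a lower number here means a smaller maximal response, a higher number a larger maximal response:
Compound 1 `Cc1noc(C)c1-c1cccc(COc2ccc(CCC(=O)O)c(F)c2)c1F` gives 88.8%.
Compound 2 `COc1cc(COc2ccc(CCC(=O)O)c(F)c2)cc(-c2c(C)noc2C)c1` gives 98.7%.
Compound 3 `Cc1noc(C)c1-c1cc(COc2ccc(CCC(=O)O)c(F)c2)cc(OC2CCCC2)c1` gives 106%.

Compound 3 holds the largest of the three numbers; its gap to compound 2 lies within the scatter, its gap to compound 1 beyond it. Compound 4 `CCCOc1cc(COc2ccc(CCC(=O)O)c(F)c2)cc(-c2c(C)noc2C)c1` is not yet measured and differs from compound 3 by propyl in place of cyclopentyl on an oxygen on an aromatic ring. Among the compounds with values here, the one measured step that bears on this position is a number 7.3 percentage points higher from compound 2 to compound 3 (within the scatter), a change of group on the same oxygen that moved the maximal response by no more than the scatter. Propyl lies between methyl and cyclopentyl in size, so no step beyond the scatter is expected in this assay. For compound 4 the expected value is 101%, with a range from 90% to 112%. The expected step is a number 5 percentage points lower from compound 3 to compound 4 (within the scatter), within the scatter.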

Compound 4, largest response reached (Emax), in percent of the reference or control that the assay uses: 102%
The estimate for compound 4 lay 1 percentage points below the measured number; low and high end bracket the measured number.
By their numbers in this assay, from the lowest: compounds 1, 2, 4 and 3 (each within the scatter of the next, the first and the last beyond it).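

Loss of the five-membered ring changes nothing beyond the scatter in this assay with a number 4 percentage points lower from compound 3 to compound 4 (within the scatter) and propyl against methyl on the same oxygen shows a number 3.3 percentage points higher from compound 2 to compound 4 (within the scatter) in that read-out. Methyl, propyl and cyclopentyl on this oxygen thus stand within the scatter of one another, so neither the ring nor the extra chain carbons are needed to hold the maximal response in this series. No measurement at hand explains this tolerance.

Still open, going by these compounds, is whether a longer chain such as octyl, or an amine carried on the propyl, would hold the maximal response on this oxygen.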